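Trading a Phenoxy for Fluoro in a Weak Series

A few compounds are considered here, and "the series" means these few. Any claim that something is new, unique, unknown or untested is made for them only; others in the source may bear on it.

Compound 1, `N[C@H]1CC[C@H](Nc2c(C(=O)NCc3ccc(Oc4ccccc4)cc3)nc(Br)c3cccnc23)CC1`, is examined in a functional assay on MCF7 cells (Homo sapiens) for cytotoxicity, read by MTT assay, with a stated time of 72 h; on this read-out higher numbers stand for weaker inhibition and lower numbers for stronger inhibition. In this assay compound 1 gives 7900 nM. Two companions have the same read-out. Compound 3, `CS(=O)(=O)NCCCCCCN(c1nc(C(=O)NCc2ccc(F)cc2)c(O)c2ncccc12)S(C)(=O)=O`, gives 7000 nM in this assay, a value that sits within the scatter of compound 1, so the two cannot be told apart. Compound 2, `NCCCNc1c(C(=O)NCc2ccc(F)cc2)ncc2cccnc12`, reaches only a limit in this assay, > 10000 nM, so for compound 2 no number is known. Compound 2 rests at the limit of > 10000 nM in this assay, at which 1 of the 3 values shown sits. Of the two numbers shown, compound 1 carries the higher figure, though its gap to compound 3 lies inside the usual scatter.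

The compound not yet measured is compound 4, `N[C@H]1CC[C@H](Nc2c(C(=O)NCc3ccc(F)cc3)nc(Br)c3cccnc23)CC1`. It differs from compound 1 in one place: fluoro in place of phenoxy on an aromatic carbon. Among the measured compounds shown here, the same fluoro group on the benzyl amide appears in compound 2 and compound 3, yet neither shares the rest of compound 1, so no measured step describes this exchange. A modest weakening is expected, of the size a 1.5-fold higher number from compound 1 to compound 4 (0.18 log units; within the scatter). Compound 4 is estimated at 12000 nM in this assay, within 5000 nM to 30000 nM.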

Compound 4, half-maximal inhibitory concentration: 2000 nM
Compound 4: the middle estimate sits 6.0-fold (0.78 log units) above what was measured; measured number outside the range, below it.
By their numbers in this assay, from the lowest: compound 4; then compounds 3 and 1 (each within the scatter of the next). At a limit, above all of these: compound 2.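

At this position, on an aromatic carbon para to a large group, fluoro in place of phenoxy gives a 4.0-fold lower number from compound 1 to compound 4 (0.60 log units; beyond the scatter) in this assay, and on this read-out the lower number means stronger inhibition. The earlier compounds shown here offered no measured step at this position, and this one shows that the phenoxy group, with its whole six-membered aromatic ring, can be replaced by a single fluorine atom without any loss in this assay; the number in fact moves beyond the usual scatter, although compound 4 still sits in the same weak range as the others. The compounds shown give no measurement that explains why the number falls.

Among the compounds shown here, with only one exchange at this position, it remains open whether the gain comes from the arrival of fluoro or simply from the departure of phenoxy, a question that a hydrogen, a chlorine or a methoxy group at the same place could help to settle. As far as these compounds go, it also remains open whether the same exchange gives a similar step on compounds that differ from compound 1 elsewhere in the molecule.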